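Halogen swap on the anilide ring of the cinnamamide series

This account rests on a few compounds, and the source may have more. Where it says the series, first, only, none or still open, it means among the compounds named here.

Two compounds of the shared core carry numbers in a functional assay on cells (Splenocyte, Mus musculus, strain BALB/c) for inhibition, read by MTT assay, with a stated time of 48 h; on this read-out higher numbers stand for weaker inhibition and lower numbers for stronger inhibition. Compound 1 `CO/C(=C\c1ccccc1)C(=O)Nc1ccc(F)cc1` gives 4940 nM. Compound 2 `CO/C(=C\c1ccc(Cl)cc1)C(=O)Nc1ccc(F)cc1` gives 14000 nM; compound 2 stands highest of the two, its nearest neighbour being compound 1, and the step of a 2.8-fold higher number from compound 1 to compound 2 (0.45 log units; beyond the scatter) is modest but beyond the scatter. Compound 3 `CO/C(=C\c1ccc(Cl)cc1)C(=O)Nc1ccc(Br)cc1` is not yet measured. It differs from compound 2 by bromo in place of fluoro on an aromatic carbon. No measured step in this assay bears on a halogen exchanged for another halogen on the anilide ring; the one step shown, a 2.8-fold higher number from compound 1 to compound 2 (0.45 log units; beyond the scatter), concerns the other ring and a different kind of change, so it offers no direction for this one. The expectation for compound 3 is therefore a step of no change at the digits printed from compound 2 to compound 3 (within the scatter), that is, none beyond the scatter. Compound 3 is estimated at 14000 nM, with a range from 5000 nM to 40000 nM.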

Compound 3, half-maximal inhibitory concentration: 11000 nM
Compound 3: middle estimate off by 1.3-fold (0.10 log units), on the high side, within the range that was stated.
By their numbers in this assay, from the lowest: compound 1; then compounds 3 and 2 (each within the scatter of the next).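

In this assay the change from 4-fluorophenyl to 4-bromophenyl gives a 1.3-fold lower number from compound 2 to compound 3 (0.10 log units; within the scatter) and so leaves the number inside the scatter, with the chloro group held fixed on the other ring. Going by these compounds alone, this is the first reading at this position, and it shows that the two halogens cannot be told apart here; the only step beyond the scatter remains a 2.8-fold higher number from compound 1 to compound 2 (0.45 log units; beyond the scatter) and belongs to the other ring. Nothing available accounts for either step.

From the compounds shown here alone, whether an amine or a carboxylic acid in place of the halogen at this position would shift the number remains open. Also open, going by these compounds, is whether the exchange of fluoro for bromo would read the same with hydrogen instead of chloro on the other ring, as in compound 1.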